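This account rests on a few compounds, and the source may have more. Where it says the series, first, only, none or still open, it means among the compounds named here.

In an assay on a cell-free system (plasma) for inhibition of Dipeptidyl peptidase 4 (Rattus norvegicus), read by fluorescence (a lower number here means a stronger inhibitor, a higher number a weaker inhibitor), compound 3, whose structure is `CN(Cc1ccc(C#N)cc1)[C@@H]1CN[C@H](C(=O)N2CCSC2)C1`, gives 13.6 nM, the lowest of the two numbers measured here. Its nearest neighbour is compound 1, with the structure `N#Cc1ccc(CN[C@@H]2CN[C@H](C(=O)N3CCSC3)C2)cc1`, which in this assay gives 34.3 nM. The two differ only by a methyl in place of a hydrogen on an amine nitrogen, and that change produced a 2.5-fold lower number from compound 1 to compound 3 (0.40 log units; beyond the scatter), a modest gain that lies beyond the usual scatter. Compound 2, with the structure `O=C([C@@H]1C[C@H](NS(=O)(=O)c2ccccc2)CN1)N1CCSC1`, reaches only > 300 nM in this assay, which is a limit of the assay rather than a number. That limit is described by the limit of > 300 nM in this assay, at which 1 of the 3 values shown sits.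

Compound 4, with the structure `CC(C)N(Cc1ccc(C#N)cc1)[C@@H]1CN[C@H](C(=O)N2CCSC2)C1`, has not yet been measured. It differs from compound 3 by isopropyl in place of methyl on an amine nitrogen. Among the compounds with values here, the only measured step touching this nitrogen is the one from hydrogen to methyl, which helped modestly; no measured pair shows what a larger group does there. A further enlargement may keep the gain or lose part of it, so no change beyond the scatter is expected in either direction. Compound 4 is therefore estimated to give 20 nM, with a range from 6 nM to 70 nM. That estimate means an expected step of a 1.5-fold higher number from compound 3 to compound 4 (0.17 log units; within the scatter), within the scatter.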

Compound 4, half-maximal inhibitory concentration: 12.5 nM
Beside the measured number, compound 4's estimate is 1.6-fold (0.20 log units) above it, and the stated range covers the measured number.
By their numbers in this assay, from the lowest: compounds 4 and 3 (each within the scatter of the next); then compound 1. At a limit, above all of these: compound 2.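

The new result shows that this amine nitrogen accepts more than a methyl in this assay: replacing methyl with isopropyl, which brings the group from 1 heavy atom to 3, gives a 1.1-fold lower number from compound 3 to compound 4 (0.04 log units; within the scatter) and so no change that can be told apart from repeat-measurement noise. Set against the hydrogen of compound 1, the isopropyl group gives a 2.7-fold lower number from compound 1 to compound 4 (0.44 log units; beyond the scatter) in the same assay, a step close in size to a 2.5-fold lower number from compound 1 to compound 3 (0.40 log units; beyond the scatter) seen with methyl, so the modest gain from substituting this nitrogen survives the enlargement. Nothing in the available evidence bears on why the larger group leaves the number where it stands.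

Going by these compounds, how much larger the group on this nitrogen can become remains open, since a cyclohexyl ring, a benzyl group or a longer chain could either hold the number or lose the gain. It is equally open whether a chain ending in a carboxylic acid or a further amine would be accepted at this nitrogen, as every substituent shown here is a small saturated carbon group.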